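The source may report more compounds than this note shows. Statements on the series, on what has been measured and on what is new or still open speak of the compounds shown alone.

Measured so far:
- compound 1 `COc1ccc(OC)c(CN(C(=O)Nc2ccc(C)cc2)n2cnnc2)c1`: in a functional assay on MCF7 cells (Homo sapiens) for cytotoxicity, read by MTT assay, with a stated time of 48 h (a lower number here means a stronger inhibitor, a higher number a weaker inhibitor), compound 1 gives > 50000 nM, which is a limit of the assay and not a number.
- compound 2 `CCCCCCCCCNC(=O)N(Cc1cc(OC)ccc1OC)n1cnnc1`: in this assay compound 2 gives > 50000 nM, likewise a limit of the assay.

Where compound 2 stands: only a limit is known for it in this assay, and the same holds for compound 1. Both values sit at the limit of > 50000 nM in this assay, at which 2 of the 2 values shown sit, so neither compound is placed on the scale by a number. Going by the values given here, the single measured step between them, a step that the two limits leave unreadable from compound 1 to compound 2, cannot be read in size or direction, and it is the only step that touches the group on the amide-type nitrogen.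

Compound 3 `COc1ccc(OC)c(CN(C(=O)NC2CCCCC2)n2cnnc2)c1` differs from compound 2 by cyclohexyl in place of nonyl on an amide-type nitrogen. Among the compounds with values here, the one step that bears on this position, a step that the two limits leave unreadable from compound 1 to compound 2, gives no readable size, so no expectation of a step beyond the scatter can be drawn from it in either direction. For this assay the working expectation for compound 3 is therefore that it stays at the limit, with a step that the limit leaves unreadable from compound 2 to compound 3 estimated as no readable change. The estimate for compound 3 in this assay is 70000 nM, expected to lie between 20000 nM and 250000 nM.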

Compound 3, half-maximal inhibitory concentration: > 50000 nM
Compound 3: no number, only a limit; the forecaster's own chance of this, stated with the estimate: 80%; the middle value lies beyond the limit too.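

In this assay compound 3 gives > 50000 nM, a limit of the assay and not a number. No new step can be read among compound 1, compound 2 and compound 3, as all three values sit at one limit: the limit of > 50000 nM in this assay, at which 3 of the 3 values shown sit.

The compounds shown leave open whether any group on the amide-type nitrogen gives a measurable value in this assay.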